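From Trifluoromethyl to Fluoro: What the Cell Assay May Show

The source may hold more compounds than are shown below. What is called first, only, known or untested is meant among the compounds shown, and "the series" means these compounds.

Compound 1 `COc1cc(C(=O)N/N=C/c2ccccc2C(F)(F)F)cc(OC)c1OC` and compound 2 `COc1cc(C2=NN(C(C)=O)C(c3cc(OC)c(OC)c(OC)c3)O2)cc(OC)c1OC` have both been tested in a functional assay on BGC-823 cells (Homo sapiens) for antiproliferative activity, read by MTT assay, tested at 1 uM; a higher number here means a stronger effect of the compound at the concentration tested, a lower number a weaker effect. In this assay compound 1 gives 22.1%, the higher of the two numbers recorded. In this assay compound 2 gives -1.8%, a number that lies beyond the usual scatter below that of compound 1, so compound 1 stands clearly stronger of the two at the concentration tested, though its own effect is still modest.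

Compound 3 `COc1cc(C(=O)N/N=C/c2ccccc2F)cc(OC)c1OC` has not yet been measured in this assay. It differs from compound 1 in one place: fluoro in place of trifluoromethyl on an aromatic carbon. The trifluoromethyl group of compound 1 gives way to fluoro at the same aromatic carbon, and nothing else in the molecule changes.

Among the measured compounds shown here, no pair of measured compounds differs in a single place, so the data contain no example of how large such a swap tends to be. For the measured compounds named here, the only anchor is compound 1 with 22.1% in this assay. The step from compound 1 to compound 3 is expected to be a number 4.1 percentage points lower from compound 1 to compound 3 (within the scatter), a change not beyond the scatter. Compound 3 is therefore estimated at 18%, with an expected range from 5% to 32%.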

Compound 3, a percentage reported as inhibition, at one concentration (the size of the read-out at that concentration, not a potency): 51.6%
Compound 3: the middle estimate sits 33.6 percentage points below what was measured, outside the stated range (above it).
By their numbers in this assay, from the lowest: compound 2; then compound 1; then compound 3.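

In this assay, among the compounds shown here, the swap of trifluoromethyl for fluoro gives a number 29.5 percentage points higher from compound 1 to compound 3 (beyond the scatter) and provides the first comparison here of two compounds that differ in one place. It shows that this aromatic carbon, ortho to a large group, is not indifferent to what it carries: a substituent of 4 heavy atoms gives way to one of 1 heavy atom, with no ring, hydrogen-bond donor, hydrogen-bond acceptor or net charge entering or leaving, and the read-out moves beyond the usual scatter. The available data offer no measurement that explains why this single change has such an effect.

As far as these compounds go, with only trifluoromethyl and fluoro to compare at this carbon, it remains open whether a chlorine atom, a methoxy group, an amine or a plain hydrogen would give a read-out nearer that of compound 1 or that of compound 3. From the compounds shown here alone, it also remains open whether fluoro would have a similar effect at another carbon of the same ring, and, since the read-out comes from one concentration, how the potencies of compound 1 and compound 3 compare.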